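Swapping the Aryl Group on a Glycine Transporter Inhibitor

A few compounds are considered here, and "the series" means these few. Any claim that something is new, unique, unknown or untested is made for them only; others in the source may bear on it.

Within the data shown here, compound 2 `COc1cc(C(F)(F)F)cc(SC)c1C(=O)NC1(c2ccc(F)cc2)CCCN(C)C1` is the only compound here with a measured number: in an assay on cells for inhibition of sodium- and chloride-dependent glycine transporter 1 (Homo sapiens) (on this read-out lower numbers stand for an effect already at smaller amounts and higher numbers for an effect only at larger amounts of compound), compound 2 gives 26 nM. Compound 1 `CN1CCCC(NC(=O)c2ccc(C(F)(F)F)cc2)(c2ccccc2)C1` returns only a limit of this assay, namely > 10000 nM, as the limit of > 10000 nM in this assay, at which 1 of the 2 values shown sits, records. Compound 3 `COc1cc(C(F)(F)F)cc(SC)c1C(=O)NC1(c2cnccn2)CCCN(C)C1` differs from compound 2 in one place: pyrazin-2-yl in place of 4-fluorophenyl on a saturated ring carbon. Among the measured compounds shown here, no step between two measured compounds is available to anchor this change, so the expected step of a 3.1-fold higher number from compound 2 to compound 3 (0.49 log units; beyond the scatter) is a modest loss, somewhat beyond the usual scatter. Compound 3 is therefore estimated at 80 nM, within a range from 20 nM to 400 nM.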

Compound 3, half-maximal effective concentration: 1670 nM
For compound 3 the middle estimate is 21-fold (1.32 log units) below the measured one; the measured number lies above the stated range.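

The ring carbon two ring bonds from the ring nitrogen is sensitive to the group it carries: in this assay, pyrazin-2-yl in place of 4-fluorophenyl gives a 64-fold higher number from compound 2 to compound 3 (1.81 log units; beyond the scatter) on otherwise unchanged molecules. The incoming ring has 2 hydrogen-bond acceptors and the outgoing ring has none, but no measurement shown explains the step.

Still open, going by these compounds, is whether pyridin-2-yl, with a single ring nitrogen, would stay closer to compound 2 or behave like compound 3. Equally open, on these data alone, is how an unsubstituted phenyl or a 4-chlorophenyl would fare at this carbon.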